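The compounds below may be only part of what the source reports. "The series", "measured", "known", "first", "only" and "open" are said of these compounds alone.

The three compounds share one core and differ only at the amide end. Compound 1 `CC(C)c1ccc(NC(=O)COc2ccc3cc(C(O)(C(F)(F)F)C(F)(F)F)c(O)cc3c2)cc1` carries a (4-isopropylphenyl)amino group; in an assay on isolated protein for inhibition of tyrosine-protein phosphatase non-receptor type 13 (Homo sapiens), read by spectrophotometry (a higher number here means a weaker inhibitor, a lower number a stronger inhibitor), compound 1 gives 6500 nM. Compound 2 `CCN(CC)C(=O)COc1ccc2cc(C(O)(C(F)(F)F)C(F)(F)F)c(O)cc2c1` carries diethylamino instead; in this assay compound 2 reaches only the limit of the assay, > 20000 nM. Compound 3 `O=C(COc1ccc2cc(C(O)(C(F)(F)F)C(F)(F)F)c(O)cc2c1)NCc1ccccc1` carries benzyl on the amide-type nitrogen; in this assay compound 3 likewise gives only a limit, > 20000 nM. So compound 3 stands at a boundary rather than at a number, a position it shares as shown by the limit of > 20000 nM in this assay, at which 2 of the 3 values shown sit. Both measured steps away from compound 1 lose potency: an at least 3.0-fold higher number from compound 1 to compound 2 (0.48 log units; beyond the scatter) and an at least 3.0-fold higher number from compound 1 to compound 3 (0.48 log units; beyond the scatter), while a step that the two limits leave unreadable from compound 2 to compound 3 cannot be read.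

Compound 4 `O=C(COc1ccc2cc(C(O)(C(F)(F)F)C(F)(F)F)c(O)cc2c1)Nc1cccc2ccccc12` follows from compound 3 by the change (naphthalen-1-yl in place of benzyl on an amide-type nitrogen). That places an aromatic group on the amide-type nitrogen again, as in compound 1, and the step of an at least 3.0-fold higher number from compound 1 to compound 3 (0.48 log units; beyond the scatter) showed the benzyl version to be the weaker of those two. Compound 4 is therefore expected to move back toward a measurable number, a step of an at least 2.5-fold lower number from compound 3 to compound 4 (0.39 log units; beyond the scatter). Compound 4 is estimated at 8000 nM, within a range from 3000 nM to 25000 nM.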

Compound 4, half-maximal inhibitory concentration: > 20000 nM
Compound 4: only a limit was reported; the forecaster's own chance of this, stated with the estimate: 35%; at least 2.5-fold (0.39 log units) between middle value and limit.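

Compound 4 shows that an aromatic group on the amide-type nitrogen is not enough on its own to give a measurable number in this assay: compound 4 gives > 20000 nM, which is a limit of the assay and not a number. Naphthalen-1-yl in place of 4-isopropylphenyl on that nitrogen gives an at least 3.0-fold higher number from compound 1 to compound 4 (0.48 log units; beyond the scatter), so among the compounds shown only the (4-isopropylphenyl)amino group of compound 1 reaches a number. The steps from compound 2 and from compound 3 to compound 4 cannot be read, and the amide end now meets one boundary with three different groups: the limit of > 20000 nM in this assay, at which 3 of the 4 values shown sit.

As far as these compounds go, it remains open whether compound 1 owes its number to the isopropyl group, to the single phenyl ring that carries it, or to both, and whether a plain phenyl, 4-methylphenyl or 4-tert-butylphenyl group on the same nitrogen would also give a number. The limits also leave open how far compound 2, compound 3 and compound 4 lie from one another.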